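The source may report more compounds than this note shows. Statements on the series, on what has been measured and on what is new or still open speak of the compounds shown alone.

Compound 1 `Cc1cn([C@@H]2O[C@H](CO[Si](C)(C)C(C)(C)C)[C@@]3(OS(=O)(=O)C=C3NCCC(=O)OCc3ccccc3)[C@H]2O[Si](C)(C)C(C)(C)C)c(=O)n(C)c1=O`. In a functional assay on CCRF-CEM cells (Homo sapiens) (a higher number here means that more compound is tolerated, a lower number that less compound is tolerated), compound 1 gives only a limit, > 250000 nM.
Compound 2 `Cc1cn([C@@H]2O[C@H](CO[Si](C)(C)C(C)(C)C)[C@@]3(OS(=O)(=O)C=C3NC(=O)c3ccccc3)[C@H]2O[Si](C)(C)C(C)(C)C)c(=O)n(C)c1=O`. In this assay compound 2 gives 4910 nM.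
Compound 3 `COC(=O)CC(=O)NC1=CS(=O)(=O)O[C@@]12[C@@H](CO[Si](C)(C)C(C)(C)C)O[C@@H](n1cc(C)c(=O)n(C)c1=O)[C@@H]2O[Si](C)(C)C(C)(C)C`. In this assay compound 3 gives 29700 nM.

Compound 3 holds the highest of the two numbers; its nearest neighbour is compound 2, reached by a 6.0-fold higher number from compound 2 to compound 3 (0.78 log units; beyond the scatter). Within the data shown here, the one further value, that of compound 1, is a limit of > 250000 nM in this assay, at which 1 of the 3 values shown sits, and not a number.

Compound 4 `Cc1cn([C@@H]2O[C@H](CO[Si](C)(C)C(C)(C)C)[C@@]3(OS(=O)(=O)C=C3NCC(N)=O)[C@H]2O[Si](C)(C)C(C)(C)C)c(=O)n(C)c1=O` is not yet measured. It differs from compound 3 in one place: carbamoylmethyl in place of ((methoxycarbonyl)methyl)carbonyl on an amine nitrogen. The amine nitrogen thus loses its carbonyl substituent and carries an alkyl group again, as it does in compound 1. The measured steps that bear on this are an at least 50-fold lower number from compound 1 to compound 2 (1.70 log units; beyond the scatter) and an at least 8.4-fold lower number from compound 1 to compound 3 (0.92 log units; beyond the scatter), both of which put a carbonyl-bearing group on that nitrogen in place of 2-(benzyloxycarbonyl)ethyl and lowered the number strongly. Read in reverse, they point to a marked rise from compound 3 to compound 4, with a real chance that compound 4 again reaches only the limit. Compound 4 is therefore expected at 120000 nM, with a range from 25000 nM to 250000 nM. This estimate corresponds to a 4.0-fold higher number from compound 3 to compound 4 (0.61 log units; beyond the scatter).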

Compound 4, half-maximal cytotoxic concentration: 14600 nM
Compound 4: the middle estimate sits 8.2-fold (0.91 log units) above what was measured; the whole stated range lies above it.
By their numbers in this assay, from the lowest: compound 2; then compound 4; then compound 3. At a limit, above all of these: compound 1.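

In this assay a saturated chain on the amine nitrogen does not by itself raise the number: carbamoylmethyl stays in the company of the two carbonyl-bearing groups, with a 2.0-fold lower number from compound 3 to compound 4 (0.31 log units; beyond the scatter) and a 3.0-fold higher number from compound 2 to compound 4 (0.47 log units; beyond the scatter). The earlier reading, which tied the lower numbers to a carbonyl placed directly on this nitrogen, fails for compound 4, and the gap to compound 1 persists with the nitrogen carrying a saturated chain in both, as an at least 17-fold lower number from compound 1 to compound 4 (1.23 log units; beyond the scatter) shows. The value of compound 1 is a limit and not a number: the limit of > 250000 nM in this assay, at which 1 of the 4 values shown sits.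

Still open, on these data alone, is whether the benzyl ester of compound 1 or the length of its chain goes with the gap, since carbamoylmethyl and 2-(benzyloxycarbonyl)ethyl differ in both the chain end and the chain length. A 2-carbamoylethyl group or a 2-carboxyethyl group on the amine nitrogen would separate these two readings.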